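This account rests on a few compounds, and the source may have more. Where it says the series, first, only, none or still open, it means among the compounds named here.

Compound 2 has the structure `NC(=O)[C@@H]1CCN1Cc1ccc(OCc2cccc(F)c2)cc1`. Going by the values given here, in an assay on Sf9 cells for inhibition of Amine oxidase [flavin-containing] A (Homo sapiens), with stated times of 15 min and 60 min (on this read-out higher numbers stand for weaker inhibition and lower numbers for stronger inhibition), compound 2 gives 26800 nM, the highest of the two numbers measured so far, which means the weakest inhibition seen. Its nearest neighbour is compound 1, with the structure `NC(=O)[C@@H]1CCN1Cc1ccc(OCc2cccc(F)c2)cc1Cl`, which in this assay gives 2130 nM. Among the compounds with values here, the only measured step that connects these two is a 13-fold higher number from compound 1 to compound 2 (1.10 log units; beyond the scatter). That step removed a chloro group from the same aromatic carbon that the next change concerns.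

Compound 3 has the structure `NC(=O)[C@@H]1CCN1Cc1ccc(OCc2cccc(F)c2)cc1F`. It differs from compound 2 by fluoro in place of hydrogen on an aromatic carbon. Within the data shown here, the single measured step bearing on this change, a 13-fold higher number from compound 1 to compound 2 (1.10 log units; beyond the scatter), shows that a halogen on this carbon went with a much lower number, so putting a halogen back is expected to bring the number down again, though fluoro is a different halogen from chloro and the size of its effect is unknown. A step of the size a 3.4-fold lower number from compound 2 to compound 3 (0.53 log units; beyond the scatter) is therefore expected, in the direction of stronger inhibition but smaller than the chloro step. For compound 3 the expected value in this assay is 8000 nM, with a range from 3000 nM to 20000 nM.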

Compound 3, half-maximal inhibitory concentration: 18600 nM
Compound 3: the middle estimate sits 2.3-fold (0.37 log units) below what was measured; low and high end bracket the measured number.
By their numbers in this assay, from the lowest: compound 1; then compounds 3 and 2 (each within the scatter of the next).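

In this assay, fluoro on the aromatic carbon ortho to the (2-carbamoylazetidin-1-yl)methyl group cannot be told apart from hydrogen: the step is a 1.4-fold lower number from compound 2 to compound 3 (0.16 log units; within the scatter) and so gives no sign that fluoro changes inhibition at this position. Chloro and fluoro on this same carbon do differ, with an 8.7-fold higher number from compound 1 to compound 3 (0.94 log units; beyond the scatter) as the step between them, so among these three compounds the stronger inhibition belongs to chloro alone and not to halogens in general. Nothing measured here accounts for this difference between the two halogens.

The compounds shown leave open how a bromo, methyl or methoxy group on this carbon would compare with chloro, and so whether chloro is a special case or one of several groups that give stronger inhibition here. From the compounds shown here alone, all three compounds also share the rest of the core, so it remains open whether the chloro step would hold if the primary amide gave way to a carboxylic acid or if the fluoro on the benzyl ring were replaced by a chloro.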